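Bromo to methoxy on a hydrazone series: cytotoxicity outlook

The source may hold more compounds than are shown below. What is called first, only, known or untested is meant among the compounds shown, and "the series" means these compounds.

Compound 1, `O=C(CSc1nnc(-c2ccncc2)o1)N/N=C/c1ccccc1`, gives 167000 nM in an ADME assay on NIH3T3 cells (Mus musculus) for cytotoxicity, read by MTT assay, with a stated time of 24 h; on this read-out lower numbers stand for stronger inhibition and higher numbers for weaker inhibition.
Compound 2, `O=C(CSc1nnc(-c2ccncc2)o1)N/N=C/c1ccc(Br)cc1`, gives 169000 nM in this assay.
Compound 3, `O=C(CSc1nnc(-c2ccncc2)o1)N/N=C/c1ccc([N+](=O)[O-])cc1`, gives 195000 nM in this assay.

All three numbers lie within the usual scatter of one another. Compound 2 has compound 1 as its nearest neighbour, a 1.0-fold higher number from compound 1 to compound 2 (0.01 log units; within the scatter), and compound 3 as its furthest, a 1.2-fold higher number from compound 2 to compound 3 (0.06 log units; within the scatter).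

Compound 4, `COc1ccc(/C=N/NC(=O)CSc2nnc(-c3ccncc3)o2)cc1`, has not yet been measured. It differs from compound 2 in one place: methoxy in place of bromo on an aromatic carbon. For the measured compounds named here, every measured step so far changes the group on this same aromatic carbon: a 1.0-fold higher number from compound 1 to compound 2 (0.01 log units; within the scatter), a 1.2-fold higher number from compound 1 to compound 3 (0.07 log units; within the scatter) and a 1.2-fold higher number from compound 2 to compound 3 (0.06 log units; within the scatter), none of them beyond the scatter. Nothing in these data suggests that a fourth group at the same spot would move the number in this assay beyond the scatter either, so the expected step is a 1.0-fold higher number from compound 2 to compound 4 (0.00 log units; within the scatter), essentially no change. Compound 4 is therefore estimated at 170000 nM, with a range from 90000 nM to 320000 nM.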

Compound 4, half-maximal inhibitory concentration: 132000 nM
Beside the measured number, compound 4's estimate is 1.3-fold (0.11 log units) above it; measured number inside the range.
By their numbers in this assay, from the lowest: compounds 4, 1, 2 and 3 (each within the scatter of the next).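

Methoxy is the first group at this aromatic carbon that enters with a hydrogen-bond acceptor, and in this assay the step stays within the scatter (a 1.3-fold lower number from compound 2 to compound 4 (0.11 log units; within the scatter)), as do the comparisons with nitro (a 1.5-fold lower number from compound 3 to compound 4 (0.17 log units; within the scatter)) and with plain hydrogen (a 1.3-fold lower number from compound 1 to compound 4 (0.10 log units; within the scatter)). Hydrogen, bromo, nitro and methoxy on this carbon, para to a large group, therefore cannot be told apart by this read-out, so the flat picture now extends to a group of two heavy atoms. No supporting data bear on why the numbers stay so close.

What the compounds shown leave open is whether a group of another kind at this carbon, such as an amine, a carboxylic acid or a longer chain, would also stay within the scatter. They also leave open whether the same holds when the bromo to methoxy change is made on a different core.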